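A few compounds are considered here, and "the series" means these few. Any claim that something is new, unique, unknown or untested is made for them only; others in the source may bear on it.

Working notes on the series. The shared core is carried by compound 1 `COc1ccc(-c2cc(/C=C/C(=O)c3ccc(N)cc3)[nH]n2)cc1` and compound 2 `COc1cc(-c2cc(/C=C/C(=O)c3ccc(N)cc3)[nH]n2)cc(OC)c1OC`; the two differ only in the substitution of the outer six-membered ring. In a functional assay on MDA-MB-468 cells (Homo sapiens) for cytotoxicity, read by sulforhodamine B assay, with a stated time of 48 h, tested at 1 uM (a higher number here means a weaker effect of the compound at the concentration tested, a lower number a stronger effect), compound 1 gives 29%. In this assay compound 2 gives 50%. Among the measured compounds shown here, compound 2 thus stands at the highest of the two numbers so far, the weaker end, and its nearest neighbour, compound 1, lies lower by a gap that is beyond the scatter. For the measured compounds named here, no step between two measured compounds differing in a single place has been established, so the two values are read only as what they show.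

The next member is compound 3 `COc1ccc(-c2cc(/C=C/C(=O)c3ccc(N)cc3)[nH]n2)cc1OC`. Relative to compound 2 the change is hydrogen in place of methoxy on an aromatic carbon, placed on an aromatic carbon of a six-membered aromatic ring of carbon only, ortho to a methoxy group, meta to a large group and meta to a methoxy group.

Compound 3 sits between compound 1 and compound 2 in methoxy count, and the step from compound 2 to compound 3 is expected as a number 10 percentage points lower from compound 2 to compound 3 (within the scatter), a modest move downward, because compound 1 gives 29% while compound 2 gives 50%. Compound 3 is therefore estimated at 40% in this assay, with a range from 25% to 56%.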

Compound 3, a percentage reported as activity, at one concentration (the size of the read-out at that concentration, not a potency): 77%
The estimate for compound 3 lay 37 percentage points below the measured number; measured number above the stated range.
By their numbers in this assay, from the lowest: compound 1; then compound 2; then compound 3.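

In this assay, hydrogen in place of methoxy on an aromatic carbon, ortho to a methoxy group, gives a number 27 percentage points higher from compound 2 to compound 3 (beyond the scatter) and so a weaker effect at the concentration tested. Methoxy in place of hydrogen on an aromatic carbon gives a number 48 percentage points higher from compound 1 to compound 3 (beyond the scatter) and also weakens the effect, so removing one methoxy group from compound 2 and adding one to compound 1 both lead to compound 3, the weakest of the three, and both steps lie beyond the scatter. The number of methoxy groups therefore does not order these compounds in one direction: compound 1 and compound 2 both lie on the stronger side of compound 3, and no measurement at hand accounts for this.

The compounds shown leave open whether the step depends on methoxy itself or would also appear with hydroxy, fluorine or a longer chain such as ethoxy on that carbon. They also leave open whether the same steps would hold with an acetamide in place of the amine on the other aromatic ring.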